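Chlorophenyl Placement on the Shared Core

The source may report more compounds than this note shows. Statements on the series, on what has been measured and on what is new or still open speak of the compounds shown alone.

Three measured compounds share one core and a 4-hydroxyphenyl group. Compound 1 `Oc1ccc(-c2cc(-c3ccccc3)nc(-c3ccccc3Cl)c2)cc1` gives 2800 nM in a functional assay on DU-145 cells (Homo sapiens) for cytotoxicity, read by CCK-8 assay and cell counting, with a stated time of 2 days; a lower number here means a stronger inhibitor, a higher number a weaker inhibitor. Compound 2 `Oc1ccc(-c2cc(-c3ccco3)nc(-c3ccccc3Cl)c2)cc1` gives 5300 nM in this assay, the highest of the three numbers shown, though not separated from either neighbour beyond the scatter. Compound 3 `Oc1ccc(-c2cc(-c3ccsc3)nc(-c3ccccc3Cl)c2)cc1` gives 3890 nM in this assay. The steps among them are a 1.9-fold higher number from compound 1 to compound 2 (0.28 log units; within the scatter), a 1.4-fold higher number from compound 1 to compound 3 (0.14 log units; within the scatter) and a 1.4-fold lower number from compound 2 to compound 3 (0.13 log units; within the scatter); each stays within the scatter, so the three numbers are not distinguished from one another.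

Compound 4 `Oc1ccc(-c2cc(-c3ccc(Cl)cc3)nc(-c3ccco3)c2)cc1` differs from compound 2 by 4-chlorophenyl in place of 2-chlorophenyl on an aromatic carbon. Within the data shown here, none of the measured steps touches this change: all three exchange the group that is phenyl in compound 1 while 2-chlorophenyl stays fixed, so no measured step bears on it. With nothing to point either way, the expected step from compound 2 to compound 4 in this assay is no change at the digits printed from compound 2 to compound 4 (within the scatter), none beyond the scatter. For compound 4 the estimate is 5300 nM, with a range of 2000 nM to 14000 nM.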

Compound 4, half-maximal inhibitory concentration: 7280 nM
Compound 4: middle estimate off by 1.4-fold (0.14 log units), on the low side, and the stated range covers the measured number.
By their numbers in this assay, from the lowest: compounds 1, 3, 2 and 4 (each within the scatter of the next, the first and the last beyond it).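

In this assay, 4-chlorophenyl in place of 2-chlorophenyl on the aromatic carbon next to the ring nitrogen gives a 1.4-fold higher number from compound 2 to compound 4 (0.14 log units; within the scatter). Among these compounds, this is the first reading at this position, as the earlier steps all exchanged the other aryl group while 2-chlorophenyl stayed fixed, and with furan-2-yl held constant, the two chlorophenyl placements are not separated. No evidence on any property of these groups accompanies this result, so the step stays a bare reading.

Still open, as far as these compounds go, is how a group without chlorine at this position, such as an unsubstituted phenyl, an aminophenyl or a carboxyphenyl, would read against compound 2 and compound 4. Also open, from the compounds shown here alone, is whether the two chlorophenyl placements stay unseparated when phenyl or thiophen-3-yl stands in place of furan-2-yl.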